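Pyrazole diester series: aryl swap toward 4-bromophenyl

The compounds below may be only part of what the source reports. "The series", "measured", "known", "first", "only" and "open" are said of these compounds alone.

Compound 3 `CCOC(=O)c1c(-c2cc3ccccc3oc2=O)nn(-c2cccc(F)c2)c1C(=O)OCC` carries a 3-fluorophenyl on an aromatic nitrogen of the shared core. In a functional assay on HeLa cells (Homo sapiens) for cytotoxicity, read by MTT assay, with a stated time of 48 h (a lower number here means a stronger inhibitor, a higher number a weaker inhibitor), compound 3 gives 68000 nM, which places it second highest of the three numbers in hand. Its nearest neighbour is compound 2 `CCOC(=O)c1c(-c2cc3ccccc3oc2=O)nn(-c2ccc(C)c(C)c2)c1C(=O)OCC`, which in this assay gives 50000 nM; the step of a 1.4-fold higher number from compound 2 to compound 3 (0.13 log units; within the scatter) lies within the scatter, so the two values cannot be ordered. Within the data shown here, compound 1 `CCOC(=O)c1c(-c2c(Cl)c3ccccc3oc2=O)nn(-c2ccc(Br)cc2)c1C(=O)OCC` gives 500000 nM in this assay; it differs from compound 3 in two places, a 4-bromophenyl and a chlorine on the coumarin-type ring, so no single step connects them and its value can only be noted as much higher.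

The step to compound 4 `CCOC(=O)c1c(-c2cc3ccccc3oc2=O)nn(-c2ccc(Br)cc2)c1C(=O)OCC` is 4-bromophenyl in place of 3-fluorophenyl on an aromatic nitrogen. Among the measured compounds shown here, the one aryl swap measured so far, from 3,4-dimethylphenyl to 3-fluorophenyl, stayed within the scatter. For the measured compounds named here, the only other compound with a 4-bromophenyl is compound 1, whose value is confounded by the second change. On this basis a small upward drift, not confidently beyond the scatter, is expected for compound 4 in this assay: the step of a 1.5-fold higher number from compound 3 to compound 4 (0.17 log units; within the scatter) is the estimate. Compound 4 is therefore expected to give about 100000 nM, with a range of 40000 nM to 300000 nM.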

Compound 4, half-maximal inhibitory concentration: 250000 nM
For compound 4 the middle estimate is 2.5-fold (0.40 log units) below the measured one; the range from low to high includes it.
By their numbers in this assay, from the lowest: compounds 2 and 3 (each within the scatter of the next); then compounds 4 and 1 (each within the scatter of the next).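

In this assay the aryl group on the aromatic nitrogen now shows a step beyond the scatter: a 3.7-fold higher number from compound 3 to compound 4 (0.57 log units; beyond the scatter) and a 5.0-fold higher number from compound 2 to compound 4 (0.70 log units; beyond the scatter), whereas the earlier swap, a 1.4-fold higher number from compound 2 to compound 3 (0.13 log units; within the scatter), stayed within it. This position is therefore not indifferent to the aryl group, and among the three groups compared here, 4-bromophenyl stands apart with the higher number, while 3-fluorophenyl and 3,4-dimethylphenyl cannot be ordered. On the other change, a 2.0-fold lower number from compound 1 to compound 4 (0.30 log units; within the scatter) lies within the scatter, so hydrogen in place of chloro on an aromatic carbon has no readable effect on this pair, and compounds 1 and 4 cannot be ordered.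

No evidence on hand bears on the reason for the aryl step. The swap from 3-fluorophenyl to 4-bromophenyl alters both the halogen and its place on the phenyl ring, so the compounds shown leave open which of the two matters; 4-fluorophenyl and 3-bromophenyl would separate them, and a phenyl carrying an amine or a carboxylic acid would test a different kind of substituent at this position.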